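Arylamino in place of piperidine: compound 3 to compound 4

The source may hold more compounds than are shown below. What is called first, only, known or untested is meant among the compounds shown, and "the series" means these compounds.

Values in a functional assay on MCF7 cells (Homo sapiens) for inhibition, read by sulforhodamine B assay; on this read-out lower numbers stand for stronger inhibition and higher numbers for weaker inhibition:
- compound 1 `COc1ccc(NC2=CC(=O)c3nc4n(c3C2=O)[C@H]2OC[C@@H](O)[C@H]2OC4)cc1` gives 5420 nM
- compound 2 `CCOc1ccccc1NC1=CC(=O)c2nc3n(c2C1=O)[C@H]1OC[C@@H](O)[C@H]1OC3` gives > 4000 nM as a limit
- compound 3 `O=C1C=C(N2CCCCC2)C(=O)c2c1nc1n2[C@H]2OC[C@@H](O)[C@H]2OC1` gives > 8000 nM as a limit

Compound 3 stands at a limit and has no number of its own. Among the compounds with values here, compound 2 also stands at a limit, which leaves compound 1 as the only compound with a number.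

The change under study leads to compound 4 `O=C1C=C(Nc2cccc(Cl)c2)C(=O)c2c1nc1n2[C@H]2OC[C@@H](O)[C@H]2OC1`, with (3-chlorophenyl)amino in place of piperidin-1-yl on a double-bonded ring carbon.

Within the data shown here, two measured steps bear on it. The first is an at least 1.4-fold higher number from compound 1 to compound 3 (0.16 log units; that floor lies within the scatter), which runs opposite to the present change, from an arylamino group to piperidin-1-yl, and its floor does not clear the scatter. The second is a step that the limit leaves unreadable from compound 1 to compound 2, which exchanges one arylamino group for another and gives no size.

The evidence therefore sets only a weak direction and no firm size. A modestly lower number is expected in this assay, resting on the value of compound 1 , 5420 nM. The expected step is an at least 2.0-fold lower number from compound 3 to compound 4 (0.30 log units; that floor lies within the scatter), and it may not exceed the scatter.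

Compound 4 is estimated at 4000 nM, with an expected range from 1300 nM to 12000 nM.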

Compound 4, half-maximal inhibitory concentration: 4720 nM
The estimate for compound 4 lay 1.2-fold (0.07 log units) below the measured number, within the range that was stated.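

In this assay the exchange of piperidin-1-yl for (3-chlorophenyl)amino on the double-bonded ring carbon is now read in its own direction, as an at least 1.6-fold lower number from compound 3 to compound 4 (0.22 log units; that floor lies within the scatter), and this gives a direction at most, with no firm size. Compound 3 stands at a limit, so that step remains a floor: the limit of > 8000 nM in this assay, at which 1 of the 4 values shown sits. The new information lies in the second arylamino group with a number of its own, a 1.1-fold lower number from compound 1 to compound 4 (0.06 log units; within the scatter), so 3-chlorophenyl and 4-methoxyphenyl on the amine nitrogen cannot be told apart in this assay.

The step between compound 2 and compound 4 cannot be read, since compound 2 stands at a limit: the limit of > 4000 nM in this assay, at which 1 of the 4 values shown sits. As far as these compounds go, it remains open whether any group at this place moves the number beyond the scatter, and a benzylamino group, a morpholin-4-yl group or a phenyl ring carrying a carboxylic acid would put that question to the shared core.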